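Trading a Single Chlorine Arm for a Double One

The source may hold more compounds than are shown below. What is called first, only, known or untested is meant among the compounds shown, and "the series" means these compounds.

Compound 1 `COc1cccc(/C=C2\CCC/C(=C\c3cccc(Cl)c3)C2=O)c1OC` carries a 3-chlorophenyl on a double-bonded chain carbon of the shared core. In an ADME assay on NHDF cells (Homo sapiens) for cytotoxicity, read by MTT assay, with a stated time of 72 h (a lower number here means a stronger inhibitor, a higher number a weaker inhibitor), compound 1 gives 21400 nM, the lowest of the two numbers reported, and its nearest neighbour is compound 2 `COc1ccc(/C=C2\CCC/C(=C\c3cccc(OC)c3OC)C2=O)cc1`, which gives 43500 nM in this assay. Compound 3 `COc1cccc(/C=C2\CCC/C(=C\c3ccc(O)cc3)C2=O)c1OC` gives only > 50000 nM, which is the limit of > 50000 nM in this assay, at which 1 of the 3 values shown sits. Exchanging the arm for 4-methoxyphenyl brings a 2.0-fold higher number from compound 1 to compound 2 (0.31 log units; beyond the scatter), and for 4-hydroxyphenyl brings an at least 2.3-fold higher number from compound 1 to compound 3 (0.36 log units; beyond the scatter); between those two oxygen-bearing arms the step is an at least 1.1-fold higher number from compound 2 to compound 3 (0.06 log units; that floor lies within the scatter).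

Compound 4 `COc1cccc(/C=C2\CCC/C(=C\c3ccc(Cl)cc3Cl)C2=O)c1OC` has not yet been measured. It differs from compound 1 in this way: 2,4-dichlorophenyl in place of 3-chlorophenyl on a double-bonded chain carbon bound to a double-bonded ring carbon. Both measured steps at that position replaced the chlorine-bearing arm with an oxygen-bearing one and raised the number by a modest amount; compound 4 instead keeps chlorine and adds a second. For the measured compounds named here, no measured pair tests an added chlorine on its own, so the expectation rests on the observation that moving away from chlorine made the number go up, and the expected step is a 1.4-fold lower number from compound 1 to compound 4 (0.15 log units; within the scatter). Compound 4 is therefore expected to give 15000 nM, within 6000 nM to 40000 nM.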

Compound 4, half-maximal inhibitory concentration: 49200 nM
Beside the measured number, compound 4's estimate is 3.3-fold (0.52 log units) below it; the measured number lies above the stated range.
By their numbers in this assay, from the lowest: compound 1; then compounds 2 and 4 (each within the scatter of the next). At a limit, above all of these: compound 3.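

The 3-chlorophenyl arm of compound 1 now turns out to be set apart from a chlorine-bearing arm as well as from the oxygen-bearing ones: in this assay, 2,4-dichlorophenyl at the double-bonded chain carbon brings a 2.3-fold higher number from compound 1 to compound 4 (0.36 log units; beyond the scatter), so chlorine on the arm does not by itself keep the number low. Exchanging the 4-methoxyphenyl arm for 2,4-dichlorophenyl brings a 1.1-fold higher number from compound 2 to compound 4 (0.05 log units; within the scatter). Compound 1 thus keeps the lowest number of the four, and compounds 2 and 4 are indistinguishable in this assay. The value of compound 3 is a limit and not a number: the limit of > 50000 nM in this assay, at which 1 of the 4 values shown sits. The resulting figure, an at least 1.0-fold lower number from compound 3 to compound 4 (0.00 log units; that floor lies within the scatter), cannot be read as a step.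

The compounds shown leave open whether the higher number of compound 4 goes with the second chlorine itself or with where the chlorines sit on the arm, since the step changes both at once. On these data alone, how an arm bearing an amine or a carboxylic acid would stand at this position in this assay also remains open.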